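Methyl for bromo on the pyridine ether of compound 2

A few compounds are considered here, and "the series" means these few. Any claim that something is new, unique, unknown or untested is made for them only; others in the source may bear on it.

In an assay on membranes from brain for displacement of a labelled ligand from Neuronal acetylcholine receptor; alpha4/beta2 (Rattus norvegicus) (on this read-out lower numbers stand for stronger inhibition and higher numbers for weaker inhibition), compound 2 `CN1CCC[C@H]1COc1cncc(Br)c1` gives 0.27 nM, the lowest of the two numbers in hand; compound 1 `CN1CCC[C@H]1COc1cncc(C(F)(F)F)c1` gives 1.83 nM. Among the measured compounds shown here, the only measured step, a 6.8-fold lower number from compound 1 to compound 2 (0.83 log units; beyond the scatter), shows that the group on this aromatic carbon moves the number beyond the scatter. For the measured compounds named here, compound 3 `Cc1cncc(OC[C@@H]2CCCN2C)c1` carries methyl in place of bromo on an aromatic carbon, a change no measured pair covers directly, so the direction is taken only loosely from compound 2 and compound 1. Compound 3 is therefore expected to show a modest rise, a 4.4-fold higher number from compound 2 to compound 3 (0.65 log units; beyond the scatter), with an estimate of 1.2 nM and a range from 0.35 nM to 4 nM.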

Compound 3, inhibition constant: 0.48 nM
For compound 3 the middle estimate is 2.5-fold (0.40 log units) above the measured one; measured number inside the range.
By their numbers in this assay, from the lowest: compounds 2 and 3 (each within the scatter of the next); then compound 1.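

In this assay, methyl in place of bromo gives a 1.8-fold higher number from compound 2 to compound 3 (0.25 log units; within the scatter), so this assay does not separate the two groups on this aromatic carbon, while methyl in place of trifluoromethyl gives a 3.8-fold lower number from compound 1 to compound 3 (0.58 log units; beyond the scatter). Of the three groups shown at this position, only trifluoromethyl stands apart, with both of its steps beyond the scatter. Nothing measured here accounts for this. Still open, as far as these compounds go, is how an amine, a nitrile or a methoxy group would behave on this carbon. Also open, from the compounds shown here alone, is whether bromo and methyl would remain this close on another carbon of the ring.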